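Replacing the Oxygen Substituent of Compound 2

This account rests on a few compounds, and the source may have more. Where it says the series, first, only, none or still open, it means among the compounds named here.

Compound 1 `CC(C)(O)CNCCCOc1ccc([C@H]2CC[C@]3(CC2)OOC2(O3)C3CC4CC(C3)CC2C4)cc1`: 11100 ng.h/mL
Compound 2 `CC(C)(O)CN1CCC(Oc2ccc([C@H]3CC[C@]4(CC3)OOC3(O4)C4CC5CC(C4)CC3C5)cc2)CC1`: 14200 ng.h/mL

Going by the values given here, in an ADME assay on the whole organism (strain FVB) for pharmacokinetics, with Mus musculus as the target, read by LC-MS, at a dose of 30 mg/kg by the oral route (on this read-out higher numbers stand for higher exposure at the dose given and lower numbers for lower exposure), compound 2 gives 14200 ng.h/mL and stands within the scatter of compound 1, the only other measured compound. Compound 3 `c1cc([C@H]2CC[C@]3(CC2)OOC2(O3)C3CC4CC(C3)CC2C4)ccc1OCCC1CCNCC1` carries 2-(piperidin-4-yl)ethyl in place of 1-(2-hydroxy-2-methylpropyl)piperidin-4-yl on an oxygen on an aromatic ring. Among the compounds with values here, one measured step bears on this change (a 1.3-fold higher number from compound 1 to compound 2 (0.11 log units; within the scatter)) and it altered the group on that same oxygen. Compound 1 and compound 2 both hold the 2-hydroxy-2-methylpropyl portion that compound 3 lacks, so no measurement speaks to its removal. No step beyond the scatter is expected, and no firm direction, so the estimated step is small (a 1.4-fold lower number from compound 2 to compound 3 (0.15 log units; within the scatter)). For compound 3 the estimate is 10000 ng.h/mL (expected range 3500 ng.h/mL to 28000 ng.h/mL).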

Compound 3, area under the concentration-time curve: 16000 ng.h/mL
Compound 3: the middle estimate sits 1.6-fold (0.20 log units) below what was measured; the measured number falls inside the stated range.
By their numbers in this assay, from the lowest: compounds 1, 2 and 3 (each within the scatter of the next).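

In this assay, 2-(piperidin-4-yl)ethyl in place of 1-(2-hydroxy-2-methylpropyl)piperidin-4-yl on an oxygen on an aromatic ring gives a 1.1-fold higher number from compound 2 to compound 3 (0.05 log units; within the scatter), so this position tolerates the loss of the 2-hydroxy-2-methylpropyl portion with no step beyond the scatter. Read against the open chain, piperidin-4-yl in place of ((2-hydroxy-2-methylpropyl)amino)methyl gives a 1.4-fold higher number from compound 1 to compound 3 (0.16 log units; within the scatter), which leaves all three groups on this oxygen within the scatter of each other. Nothing shown here explains why the change leaves the exposure so little altered.

The compounds shown leave open how 1-(2-hydroxy-2-methylpropyl)piperidin-4-yl compares with plain piperidin-4-yl on the same oxygen, which would isolate the 2-hydroxy-2-methylpropyl portion. They also leave open how a carboxylic acid or a longer chain would read at this position.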